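A few compounds are considered here, and "the series" means these few. Any claim that something is new, unique, unknown or untested is made for them only; others in the source may bear on it.

Compounds measured so far:
compound 1, `CCOC(=O)C1=Cc2ccccc2OC1(OCc1cc(-c2ccc3ccccc3c2)no1)C(F)(F)F`, 65400 nM
compound 2, `CCOC(=O)C1=Cc2ccccc2OC1(OCc1cc(-c2ccc(Cl)cc2)no1)C(F)(F)F`, 18200 nM

In a functional assay on MCF7 cells (Homo sapiens) for inhibition, read by MTT assay, with a stated time of 24 h (on this read-out lower numbers stand for stronger inhibition and higher numbers for weaker inhibition), compound 1 gives 65400 nM, and compound 2 gives 18200 nM. Within the data shown here, the single measured step is a 3.6-fold lower number from compound 1 to compound 2 (0.56 log units; beyond the scatter), a modest step that lies beyond the scatter. On the two numbers shown, compound 2 stands lowest, with compound 1 as its only neighbour.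

Compound 3, `CCOC(=O)C1=Cc2ccccc2OC1(OCc1cc(-c2ccc([N+](=O)[O-])cc2)no1)C(F)(F)F`, has not yet been tested. It differs from compound 2 in one place: nitro in place of chloro on an aromatic carbon. Among the measured compounds shown here, nothing among the measured pairs touches this exchange; the only known step concerns the group carried on the same aromatic carbon, where the naphthalen-2-yl of compound 1 was swapped for 4-chlorophenyl, and it gave a modest change. For the measured compounds named here, no measured pair compares chloro with nitro on this ring, so there is no basis for a large step in either direction.

Compound 3 is therefore expected to lie close to compound 2, with the step of a 1.1-fold higher number from compound 2 to compound 3 (0.04 log units; within the scatter) estimated to fall within the scatter. The estimate for compound 3 in this assay is 20000 nM, in the range 7000 nM to 60000 nM.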

Compound 3, half-maximal inhibitory concentration: > 150000 nM
Compound 3: a limit, no number; the forecaster's own chance of this, stated with the estimate: 10%; at least 7.5-fold (0.87 log units) between middle value and limit.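

In this assay compound 3 gives a limit of the assay and not a number: the limit of > 150000 nM in this assay, at which 1 of the 3 values shown sits. At this aromatic carbon, para to a large group, the exchange of chloro for nitro gives an at least 8.2-fold higher number from compound 2 to compound 3 (0.91 log units; beyond the scatter) and so shows that the read-out responds to a change of this one substituent, whereas the earlier step, a 3.6-fold lower number from compound 1 to compound 2 (0.56 log units; beyond the scatter), concerned the whole group of naphthalen-2-yl against 4-chlorophenyl. The third pair gives an at least 2.2-fold higher number from compound 1 to compound 3 (0.36 log units; beyond the scatter), which puts the three groups in a clear order on this read-out, with 4-chlorophenyl giving the strongest inhibition, naphthalen-2-yl weaker inhibition and 4-nitrophenyl the weakest.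

Going by these compounds, since compound 3 gives only a limit, the true size of both its steps stays open, as does whether the nitro group itself or the absence of chloro accounts for the difference. With only chloro and nitro compared on this ring, the compounds shown also leave open how a bare hydrogen, a fluoro, a methoxy or an amine at this carbon would read.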